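Series notes: shortening the hydroxy-bearing chain, compound 2 to 3

This account rests on a few compounds, and the source may have more. Where it says the series, first, only, none or still open, it means among the compounds named here.

Compound 1 `CCCCc1cn(C(c2ccccc2)c2cc3cc(Br)ccc3nc2OC)nn1`: 5.46%
Compound 2 `COc1nc2ccc(Br)cc2cc1C(c1ccccc1)n1cc(CCCO)nn1`: 25.5%

Within the data shown here, in an ADME assay on PANC-1 cells (Homo sapiens) for cytotoxicity, read by sulforhodamine B assay, with a stated time of 48 h, tested at 10 uM (on this read-out higher numbers stand for more inhibition at the one concentration tested (going by the name of the read-out) and lower numbers for less inhibition), compound 2 stands highest of the two numbers, with compound 1 the nearest and lower; the one step measured, a number 20 percentage points higher from compound 1 to compound 2 (beyond the scatter), is beyond the scatter. Compound 3 `COc1nc2ccc(Br)cc2cc1C(c1ccccc1)n1cc(CCO)nn1` differs from compound 2 by hydroxy in place of hydroxymethyl on a saturated chain carbon, two bonds along the chain from an aromatic carbon. Among the measured compounds shown here, no measured step shortens this chain, so the step from compound 1 gives only indirect guidance. With the hydroxy kept, a change within the scatter or a small drop is expected: a number 5.5 percentage points lower from compound 2 to compound 3 (within the scatter). Compound 3 is thus estimated at 20%, range 5% to 38%.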

Compound 3, a percentage reported as inhibition, at one concentration (the size of the read-out at that concentration, not a potency): 19.8%
Estimate against measurement, compound 3: 0.2 percentage points above; measured number inside the range.
By their numbers in this assay, from the lowest: compound 1; then compounds 3 and 2 (each within the scatter of the next).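

In this assay, shortening 3-hydroxypropyl to 2-hydroxyethyl gives a number 5.7 percentage points lower from compound 2 to compound 3 (within the scatter), so this one change in chain length does not separate the two hydroxy compounds. The shorter hydroxy chain still keeps its distance from the hydroxy-free chain, with a number 14.3 percentage points higher from compound 1 to compound 3 (beyond the scatter), so the step up from compound 1 is seen with both hydroxy chain lengths. Nothing available accounts for these numbers.

Open, as far as these compounds go, is whether an amine or a carboxylic acid at the chain end would read like the hydroxy. From the compounds shown here alone, a longer hydroxy-bearing chain also remains untested in these compounds, and a single concentration gives no potency.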